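The compounds below may be only part of what the source reports. "The series", "measured", "known", "first", "only" and "open" are said of these compounds alone.

Three members of the series have been run in an ADME assay on HeLa cells (Homo sapiens) for cytotoxicity, read by ATP content, with a stated time of 3 days; on this read-out lower numbers stand for higher toxicity in this test and higher numbers for lower toxicity in this test: compound 1 `O=c1n(Cc2cc3ccncc3n2CCCCO)c2cnccc2n1C1CC1`, compound 2 `O=c1n(Cc2nc3nc(Cl)ccc3n2CCCCO)c2cnccc2n1C1CC1` and compound 3 `O=c1n(Cc2cc3cnccc3n2CCCCF)c2cnccc2n1C1CC1`. Compound 1 reaches only the limit of > 100000 nM, not a number. Compound 2 likewise gives only a limit, > 50000 nM. Compound 3 also stops at a limit, > 50000 nM. With every value at a limit (the limit of > 100000 nM in this assay, at which 1 of the 3 values shown sits, (the limit of > 50000 nM in this assay, at which 2 of the 3 values shown sit)), compound 2 cannot be placed above or below the others on the numbers shown, and no step between measured compounds can be read off.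

Compound 4 `CC(C)CCn1c(Cn2c(=O)n(C3CC3)c3ccncc32)nc2nc(Cl)ccc21` is not yet measured. It differs from compound 2 in one place: isopropyl in place of 2-hydroxyethyl on a saturated chain carbon, two bonds along the chain from an aromatic nitrogen. Within the data shown here, no measured step speaks to such a change, so the expected step of a number no higher from compound 2 to compound 4 (the limit leaves the size open) in this assay is set at no change beyond the usual scatter, leaning if anything toward a lower number. Compound 4 is therefore expected near 50000 nM, within 15000 nM to 100000 nM, with a fair chance that only a limit is reported.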

Compound 4, half-maximal cytotoxic concentration: > 50000 nM
Compound 4 gave a limit, no number (the forecaster's own chance of this, stated with the estimate: 55%); the middle value lies on the limit itself.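

Among these compounds, compound 2 and compound 4 each give only a limit in this assay, so no step between them can be read. The compounds shown leave open whether isopropyl in place of 2-hydroxyethyl shifts the read-out at all, and whether any series member would give a number.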